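The source may report more compounds than this note shows. Statements on the series, on what has been measured and on what is new or still open speak of the compounds shown alone.

Measured so far:
compound 1, `C/N=C(/NC#N)NCCCCCCn1nc(-c2ccccc2)ccc1=O`: > 100 mg/kg
compound 2, `NC(=O)SCCCCCN1NC=CC=C1c1ccccc1`: 18.3 mg/kg
compound 3, `C/N=C(\S)NCCCCn1nc(-c2ccccc2)ccc1=O`: 17.3 mg/kg

In a functional assay on the whole organism with Rattus norvegicus as the target (a higher number here means that more compound is needed for the effect, a lower number that less compound is needed), compound 1 gives only a limit of the assay, > 100 mg/kg, not a number. Compound 1 stands at the limit of > 100 mg/kg in this assay, at which 1 of the 3 values shown sits. Compound 2 and compound 3 each return a number in this assay. Compound 4, `CN(C)/C(=N/CCCCCCn1nc(-c2ccccc2)ccc1=O)NC#N`, differs from compound 1 in one place: a group of 8 heavy atoms (4 carbon, 4 nitrogen; no ring) in place of a group of 7 heavy atoms (3 carbon, 4 nitrogen; no ring), on a saturated chain carbon, six bonds along the chain from an aromatic nitrogen. Among the compounds with values here, no two measured compounds differ in a single place, so no step size can be read from the measured set. The change is expected to move the dose by nothing beyond the scatter, leaving compound 4 near the limit. For compound 4 the dose is estimated at 100 mg/kg, with a range from 30 mg/kg to 300 mg/kg. The step of a number no higher from compound 1 to compound 4 (the limit leaves the size open) is expected to be none beyond the scatter.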

Compound 4, dose for half-maximal effect: 92.5 mg/kg
Compound 4: the middle estimate sits 1.1-fold (0.03 log units) above what was measured, within the range that was stated.
By their numbers in this assay, from the lowest: compounds 3 and 2 (each within the scatter of the next); then compound 4. At a limit, above all of these: compound 1.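

In this assay, a group of 8 heavy atoms (4 carbon, 4 nitrogen; no ring) in place of a group of 7 heavy atoms (3 carbon, 4 nitrogen; no ring), on a saturated chain carbon, six bonds along the chain from an aromatic nitrogen, gives an at least 1.0-fold lower number from compound 1 to compound 4 (0.03 log units; that floor lies within the scatter). With this change, compound 4 gives the position a first number, 92.5 mg/kg. Compound 1 remains a limit of the assay, not a number, so the true size of the step stays unknown: the limit of > 100 mg/kg in this assay, at which 1 of the 4 values shown sits.

As far as these compounds go, whether a primary amine, a carboxylic acid or a longer chain would lower the dose at this position remains open.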